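Aryl swap on the piperazine nitrogen, compound 3 to compound 4

The source may hold more compounds than are shown below. What is called first, only, known or untested is meant among the compounds shown, and "the series" means these compounds.

Measured so far:
compound 1 `Nc1scc(CN2CCN(c3ccccc3C(F)(F)F)CC2)c1C(=O)c1ccc(Cl)cc1`, -7.5%
compound 2 `Nc1scc(CN2CCN(c3ccc(Cl)c(C(F)(F)F)c3)CC2)c1C(=O)c1ccc(Cl)cc1`, -12%
compound 3 `Nc1scc(CN2CCN(c3ccc(F)c(Cl)c3)CC2)c1C(=O)c1ccc(Cl)cc1`, -21%

In a functional assay on CHO cells with adenosine receptor A1 (Homo sapiens) as the target, read by cAMP accumulation and immunoassay, with a stated time of 6 min, tested at 0.1 uM (a higher number here means a weaker effect of the compound at the concentration tested, a lower number a stronger effect), compound 3 stands lowest of the three numbers; against compound 2 the gap is a number 9 percentage points lower from compound 2 to compound 3 (within the scatter), against compound 1 it is a number 13.5 percentage points lower from compound 1 to compound 3 (beyond the scatter). Compound 4 `Nc1scc(CN2CCN(c3cc(Cl)ccc3Cl)CC2)c1C(=O)c1ccc(Cl)cc1` differs from compound 3 by 2,5-dichlorophenyl in place of 3-chloro-4-fluorophenyl on an amine nitrogen in a ring. Within the data shown here, the only step beyond scatter, a number 13.5 percentage points lower from compound 1 to compound 3 (beyond the scatter), moved away from 2-(trifluoromethyl)phenyl; compound 4 returns to an aryl whose name, like that in compound 1, places a group at ring position 2, so a partial reversal is expected. For compound 4 the estimate is -13%, range -27% to 1%, a step of a number 8 percentage points higher from compound 3 to compound 4 (within the scatter) that is expected to stay within scatter.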

Compound 4, a percentage reported as activity, at one concentration (the size of the read-out at that concentration, not a potency): -6.2%
Estimate against measurement, compound 4: 6.8 percentage points below; the measured number falls inside the stated range.
By their numbers in this assay, from the lowest: compounds 3, 2, 1 and 4 (each within the scatter of the next, the first and the last beyond it).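

In this assay the change to 2,5-dichlorophenyl (a number 14.8 percentage points higher from compound 3 to compound 4 (beyond the scatter)) shows that the aryl at this position can also raise the read-out beyond the scatter. 2,5-Dichlorophenyl is not separated from 2-(trifluoromethyl)phenyl (a number 1.3 percentage points higher from compound 1 to compound 4 (within the scatter)), but it is not separated from 4-chloro-3-(trifluoromethyl)phenyl either (a number 5.8 percentage points higher from compound 2 to compound 4 (within the scatter)), so compound 2 goes against any split based on the group at ring position 2. Where an aryl bearing a methoxy group or an amine would fall in this series remains open. No evidence at hand accounts for these differences.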